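Replacing formyl with a hydroxypyrrolidinylmethyl group in a stilbene series

The source may hold more compounds than are shown below. What is called first, only, known or untested is meant among the compounds shown, and "the series" means these compounds.

Compound 1 `COc1ccc(/C=C\c2cc(OC)c(OC)c(OC)c2)cc1OCc1ccc(C=O)cc1`: 46000 nM in an ADME assay on HEK293 cells (Homo sapiens) for cytotoxicity, read by CCK-8 assay, with a stated time of 48 h; on this read-out higher numbers stand for weaker inhibition and lower numbers for stronger inhibition
Compound 2 `COc1ccc(/C=C\c2cc(OC)c(OC)c(OC)c2)cc1OCc1ccc(CNCCN(C)C)cc1`: 39000 nM in this assay
Compound 3 `COc1ccc(/C=C\c2cc(OC)c(OC)c(OC)c2)cc1OCc1ccc(CN2CC[C@@H](C(=O)O)C2)cc1`: 27000 nM in this assay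

Compound 1 has the highest number of the three, yet its steps to compound 2 a 1.2-fold lower number from compound 1 to compound 2 (0.07 log units; within the scatter) and to compound 3 a 1.7-fold lower number from compound 1 to compound 3 (0.23 log units; within the scatter) both lie within the scatter, as does the step of a 1.4-fold lower number from compound 2 to compound 3 (0.16 log units; within the scatter). Compound 4 `COc1ccc(/C=C\c2cc(OC)c(OC)c(OC)c2)cc1OCc1ccc(CN2CC[C@@H](O)C2)cc1` differs from compound 1 in one place: (3-hydroxypyrrolidin-1-yl)methyl in place of formyl on an aromatic carbon. The closest parallel is the step from compound 1 to compound 3, which put (3-carboxypyrrolidin-1-yl)methyl in place of formyl and was a 1.7-fold lower number from compound 1 to compound 3 (0.23 log units; within the scatter). The expected step is accordingly a 1.4-fold lower number from compound 1 to compound 4 (0.16 log units; within the scatter), nothing beyond the scatter. Compound 4 is estimated at 32000 nM, with a range from 15000 nM to 70000 nM.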

Compound 4, half-maximal inhibitory concentration: > 50000 nM
Compound 4: only a limit was reported; the forecaster's own chance of this, stated with the estimate: 10%; at least 1.5-fold (0.19 log units) between middle value and limit.
By their numbers in this assay, from the lowest: compounds 3, 2 and 1 (each within the scatter of the next). At a limit, above all of these: compound 4.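

In this assay compound 4 gives a limit and not a number: the limit of > 50000 nM in this assay, at which 1 of the 4 values shown sits. The (3-hydroxypyrrolidin-1-yl)methyl group on this aromatic carbon therefore gives no sign of stronger inhibition than formyl, with an at least 1.0-fold higher number from compound 1 to compound 4 (0.03 log units; that floor lies within the scatter), and the same holds against the side chain of the secondary amine, with an at least 1.2-fold higher number from compound 2 to compound 4 (0.10 log units; that floor lies within the scatter). On the saturated ring carbon, hydroxy in place of carboxy gives an at least 1.8-fold higher number from compound 3 to compound 4 (0.26 log units; that floor lies within the scatter), so these floors do not separate compound 4 from the others. As far as these compounds go, how far compound 4 lies past its limit stays open. So does how an unsubstituted pyrrolidine or a morpholine would read at this position.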